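From Compound 2 to Compound 3: An Exchanged Group on the Core

This account rests on a few compounds, and the source may have more. Where it says the series, first, only, none or still open, it means among the compounds named here.

In a functional assay on the whole organism with Rattus norvegicus as the target (on this read-out higher numbers stand for an effect only at larger amounts of compound and lower numbers for an effect already at smaller amounts), compound 1 (`CCOCCOC(=O)C(=O)Nc1nc(-c2cc(Br)no2)cs1`) gives 11 mg/kg, while compound 2 (`CCOCCOC(=O)C(=O)Nc1nc(-c2cc(COC)no2)cs1`) gives 2.4 mg/kg, the lower of the two numbers. Among the compounds with values here, the only measured step, a 4.6-fold lower number from compound 1 to compound 2 (0.66 log units; beyond the scatter), is modest and comes with methoxymethyl in place of bromo on an aromatic carbon.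

Compound 3 (`CCOCCOC(=O)C(=O)Nc1nc(-c2cc(C)on2)cs1`) carries 5-methyl-1,2-oxazol-3-yl in place of 3-(methoxymethyl)-1,2-oxazol-5-yl on an aromatic carbon of the shared core: 5-methyl-1,2-oxazol-3-yl in place of 3-(methoxymethyl)-1,2-oxazol-5-yl on an aromatic carbon. The measured step bears on this change only indirectly. Within the data shown here, it shows that changing this group can move the number, yet no measured compound carries the entering group. The methoxymethyl group present in compound 2 at 2.4 mg/kg leaves, so some return toward the higher number of compound 1 at 11 mg/kg seems likely. A step in that direction, no larger than the measured one, is therefore expected. The expected step is a 2.5-fold higher number from compound 2 to compound 3 (0.40 log units; beyond the scatter). For compound 3 the estimated value is 6 mg/kg, with an expected range from 2 mg/kg to 18 mg/kg.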

Compound 3, dose for half-maximal effect: 1.3 mg/kg
Beside the measured number, compound 3's estimate is 4.6-fold (0.66 log units) above it; measured number outside the range, below it.
By their numbers in this assay, from the lowest: compounds 3 and 2 (each within the scatter of the next); then compound 1.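

In this assay, the exchange on the aromatic carbon next to the ring nitrogen gives a 1.8-fold lower number from compound 2 to compound 3 (0.27 log units; within the scatter), so 5-methyl-1,2-oxazol-3-yl, with 6 heavy atoms, holds the level reached by 3-(methoxymethyl)-1,2-oxazol-5-yl, with 8, and the methoxymethyl group is not required for a number at this level among these compounds. Measured against the bromo compound, the same group gives an 8.5-fold lower number from compound 1 to compound 3 (0.93 log units; beyond the scatter), which places 3-bromo-1,2-oxazol-5-yl apart from both of the other groups, with compound 1 carrying the highest number of the three. Nothing available on these compounds accounts for why the exchanged groups read as they do.

From the compounds shown here alone, what remains open is how much of the result belongs to the point of attachment of the ring and how much to the group it carries, as the names show that the 3-yl and 5-yl attachments and the methyl and methoxymethyl groups change together here. Going by these compounds, it is also open how an amine, a carboxylic acid or a longer alkyl chain on the 1,2-oxazole ring would read in this assay.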